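The source may report more compounds than this note shows. Statements on the series, on what has been measured and on what is new or still open speak of the compounds shown alone.

Working notes on the series. Among the compounds with values here, the only number in hand comes from compound 1 `Cn1nccc1-c1cccc2c1CCCN2c1ccc(C#N)c(C(F)(F)F)c1`, which in a functional assay on PC-3 cells (Homo sapiens) for antiproliferative activity, read by CCK-8 assay, with a stated time of 6 days (a higher number here means a weaker inhibitor, a lower number a stronger inhibitor), gives 9800 nM. Compound 2 `CCN(c1ccc(C#N)c(Cl)c1)c1cc(-c2ccccc2)ccc1C`, the direct parent of the step followed here, has no result in this assay: for compound 2 the entry reads "not determined" (no result reported), so it stands nowhere on the numbers shown and offers no anchor of its own. Compound 3 `CCN(c1ccc(C#N)c(Cl)c1)c1cc(-n2ccnc2)ccc1C` differs from compound 2 in one place: 1H-imidazol-1-yl in place of phenyl on an aromatic carbon. Within the data shown here, no step between two measured compounds is available, so the size and direction of the change from compound 2 to compound 3 in this assay cannot be read from the series; the working assumption is a step of no more than the usual scatter in either direction. For compound 3 the expected value in this assay is 8000 nM, with a range of 2000 nM to 30000 nM, leaning on the weak inhibition seen for compound 1 at 9800 nM.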

Compound 3, half-maximal inhibitory concentration: > 30000 nM
Compound 3 gave a limit, no number (the forecaster's own chance of this, stated with the estimate: 30%); at least 3.7-fold (0.57 log units) between middle value and limit.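

In this assay no step can be read from compound 2 to compound 3, as compound 2 offers no number. Compound 3 gives > 30000 nM as a limit, not a number. The compounds shown leave open how phenyl and 1H-imidazol-1-yl compare in this position.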